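Amide-nitrogen group swap on compound 1: working notes

The source may report more compounds than this note shows. Statements on the series, on what has been measured and on what is new or still open speak of the compounds shown alone.

Measured so far in a physicochemical assay for lipophilicity, at pH 7.4 (a lower number here means a more polar compound, a higher number a more lipophilic compound), for this series:
- compound 1 `COc1ccc(NC(=O)[C@H]2CCCN2C(=O)C2(c3cccc(Cl)c3)CCCC2)nc1` (6.8)
- compound 2 `COc1ccc(C2(C(=O)N3CCC[C@@H]3C(=O)Nc3ccc4[nH]ncc4n3)CCC2)cc1` (3.9)

Compound 1 is the higher of the two, and its gap to compound 2 lies beyond the usual scatter. The next compound to be read in this assay is compound 3 `O=C(Nc1ccc2[nH]ncc2c1)[C@H]1CCCN1C(=O)C1(c2cccc(Cl)c2)CCCC1`, which differs from compound 1 in one place (1H-indazol-5-yl in place of 5-methoxypyridin-2-yl on an amide-type nitrogen), with 1H-indazol-5-yl in place of 5-methoxypyridin-2-yl on an amide-type nitrogen.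

Among the compounds with values here, no step between measured compounds that differ in one place is available to calibrate this change. Within the data shown here, the only lower reference is compound 2 (3.9), and compound 3 is expected to remain nearer to compound 1 (6.8) than to that reference. A downward step of moderate size is expected, beyond the scatter, and the estimated step (a number 0.60 log units lower from compound 1 to compound 3 (beyond the scatter)) carries wide uncertainty. For compound 3 the expected value is 6.2 within an estimated range of 5.4 to 6.9 pending measurement.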

Compound 3, distribution coefficient: 5.4
Estimate against measurement, compound 3: 0.80 log units above; the measured number falls inside the stated range.
By their numbers in this assay, from the lowest: compound 2; then compound 3; then compound 1.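

At this amide-type nitrogen, this assay now has its first one-place step: 1H-indazol-5-yl in place of 5-methoxypyridin-2-yl gives a number 1.40 log units lower from compound 1 to compound 3 (beyond the scatter), so the number at this position depends on the group it carries. The number falls although the entering group has 9 heavy atoms against 8 in the leaving group, and it has 1 hydrogen-bond donor where the leaving group has 0. No measurement bears on which feature of the swap accounts for the step.

With a single pair at this position, the contributions of the donor, the ring change and the loss of the methoxy group cannot be separated. Going by these compounds, how a plain phenyl group or a benzoic acid group would read at this amide-type nitrogen remains open.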